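Methyl in Place of Chloro on a Pair at the Limit

The source may hold more compounds than are shown below. What is called first, only, known or untested is meant among the compounds shown, and "the series" means these compounds.

Compound 1, `O=c1cc(CSc2nc3ccccc3s2)oc2ccccc12`: in a functional assay on HeLa cells (Homo sapiens) for cytotoxicity, read by MTT assay, with a stated time of 72 h (a lower number here means a stronger inhibitor, a higher number a weaker inhibitor), compound 1 gives > 25000 nM, which is a limit of the assay and not a number.
Compound 2, `O=c1cc(CSc2nc3ccccc3s2)oc2ccc(Cl)cc12`: in this assay compound 2 gives > 25000 nM, again a limit and not a number.

Compound 2 therefore stands nowhere on a scale of numbers; it sits at the limit, as does compound 1, which is all that the limit of > 25000 nM in this assay, at which 2 of the 2 values shown sit, records. Going by the values given here, the one measured step, a step that the two limits leave unreadable from compound 1 to compound 2, cannot be read because both ends are limits.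

Compound 3, `Cc1ccc2oc(CSc3nc4ccccc4s3)cc(=O)c2c1`, differs from compound 2 by methyl in place of chloro on an aromatic carbon. Among the compounds with values here, no measured step bears on this exchange, and the only step in the set is itself unreadable. The expectation is that the change from compound 2 to compound 3 leaves the result where it was, with a step that the limit leaves unreadable from compound 2 to compound 3 that is no more than a placeholder in this assay, and that compound 3 is most likely to return a limit once more. Should a number appear, compound 3 is estimated at 40000 nM, within a range from 10000 nM to 150000 nM.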

Compound 3, half-maximal inhibitory concentration: > 25000 nM
Compound 3: a limit, no number; the forecaster's own chance of this, stated with the estimate: 80%; the middle value is on the limit's open side.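

Compound 3 joins compound 1 and compound 2 at a limit, so neither the step from compound 2 to compound 3 nor the step from compound 1 to compound 3 can be read; all three share one entry: the limit of > 25000 nM in this assay, at which 3 of the 3 values shown sit.

The compounds shown leave open whether hydrogen, chloro and methyl on this aromatic carbon differ at all.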